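This account rests on a few compounds, and the source may have more. Where it says the series, first, only, none or still open, it means among the compounds named here.

Compound 1 `COc1cccc(NC(=O)COc2ccc3cc(/C=C4/SC(=O)NC4=O)ccc3c2)c1` is the reference point of this account. In an assay on isolated protein for inhibition of histone deacetylase 4 (Homo sapiens), with a stated time of 1 h (on this read-out higher numbers stand for weaker inhibition and lower numbers for stronger inhibition), compound 1 gives 1600 nM, the smallest of the three numbers recorded, although the steps to its two companions stay within the usual scatter. Compound 2 `O=C(COc1ccc2cc(/C=C3/SC(=O)NC3=O)ccc2c1)Nc1cccc(C(F)(F)F)c1` gives 2500 nM, and compound 3 `O=C(COc1ccc2cc(/C=C3/SC(=O)NC3=O)ccc2c1)Nc1ccc([N+](=O)[O-])cc1` gives 1700 nM. The three measured steps are all modest: a 1.6-fold higher number from compound 1 to compound 2 (0.19 log units; within the scatter), a 1.1-fold higher number from compound 1 to compound 3 (0.03 log units; within the scatter) and a 1.5-fold lower number from compound 2 to compound 3 (0.17 log units; within the scatter).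

Compound 4 `O=C(COc1ccc2cc(/C=C3/SC(=O)NC3=O)ccc2c1)Nc1ccc(F)cc1` has not yet been measured. It differs from compound 1 in one place: 4-fluorophenyl in place of 3-methoxyphenyl on an amide-type nitrogen. Among the measured compounds shown here, the step that bears most directly on this change is the one from compound 1 to compound 3, where 3-methoxyphenyl was likewise exchanged for a 4-substituted phenyl on the amide-type nitrogen, and that step was a 1.1-fold higher number from compound 1 to compound 3 (0.03 log units; within the scatter). The exchange of one 4-substituted phenyl for a 3-substituted one, from compound 2 to compound 3, was also a 1.5-fold lower number from compound 2 to compound 3 (0.17 log units; within the scatter). Every change of the aryl group seen so far has therefore left this assay essentially unmoved.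

On that basis, compound 4 is expected to show a step of a 1.1-fold higher number from compound 1 to compound 4 (0.05 log units; within the scatter), nothing beyond the scatter. The estimate for compound 4 in this assay is 1800 nM, with a likely range from 900 nM to 3600 nM.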

Compound 4, half-maximal inhibitory concentration: 1600 nM
For compound 4 the middle estimate is 1.1-fold (0.05 log units) above the measured one; low and high end bracket the measured number.
By their numbers in this assay, from the lowest: compounds 1, 4, 3 and 2 (each within the scatter of the next).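

In this assay the exchange of 3-methoxyphenyl for 4-fluorophenyl on the amide-type nitrogen gives no change at the digits printed from compound 1 to compound 4 (within the scatter) even though the group that enters counts no hydrogen-bond acceptor and the group that leaves counts one, so this difference in count goes with no readable shift here. Compounds 3 and 4 also allow a comparison of two substituents on a 4-substituted phenyl, and fluoro in place of nitro on an aromatic carbon gives a 1.1-fold lower number from compound 3 to compound 4 (0.03 log units; within the scatter) as its result. The exchange of 3-(trifluoromethyl)phenyl for 4-fluorophenyl gives a 1.6-fold lower number from compound 2 to compound 4 (0.19 log units; within the scatter) as well, which leaves all four aryl groups on this nitrogen within the scatter of one another, and nothing at hand explains this flat picture.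

From the compounds shown here alone, none of the four compounds carries an amine or a carboxylic acid on the aryl group, and none has a longer chain in its place, so it remains open whether such a change would move the number beyond the scatter. The shared core is also the same throughout, which leaves the effect of any change there open too.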